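A few compounds are considered here, and "the series" means these few. Any claim that something is new, unique, unknown or untested is made for them only; others in the source may bear on it.

In a functional assay on MCF7 cells (Homo sapiens) for antiproliferative activity, read by MTT assay, with a stated time of 48 h (on this read-out lower numbers stand for stronger inhibition and higher numbers for weaker inhibition), compound 1 `O=C(/C=C/c1ccc2c(c1)OCCO2)NS(=O)(=O)c1ccccc1` gives 2.16 ug/mL and compound 3 `O=C(/C=C/c1ccc2c(c1)OCCCO2)NS(=O)(=O)c1ccccc1` gives 53.9 ug/mL, the higher of the two actual numbers. Compound 2 `O=C(/C=C/c1ccc2c(c1)OCCO2)NS(=O)(=O)c1ccc(Br)cc1` reads > 100 ug/mL, which is a limit of the assay. Bromo in place of hydrogen on an aromatic carbon thus brought an at least 46-fold higher number from compound 1 to compound 2 (1.66 log units; beyond the scatter), a large step toward weaker inhibition. Compound 4 `O=C(/C=C/c1ccc2c(c1)OCCCO2)NS(=O)(=O)c1ccc(Cl)cc1` differs from compound 3 by chloro in place of hydrogen on an aromatic carbon, the change from phenyl to 4-chlorophenyl. Within the data shown here, the bromo step, taken on a different core, is the only measured guide, so a smaller move in the same direction is expected. The expected step is a 2.4-fold higher number from compound 3 to compound 4 (0.38 log units; beyond the scatter), toward weaker inhibition. For compound 4 the estimate is 130 ug/mL, with an expected range of 40 ug/mL to 400 ug/mL.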

Compound 4, half-maximal inhibitory concentration: > 100 ug/mL
Compound 4: no number, only a limit; the forecaster's own chance of this, stated with the estimate: 55%; the middle value is on the limit's open side.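

The change from phenyl to 4-chlorophenyl gives an at least 1.8-fold higher number from compound 3 to compound 4 (0.26 log units; that floor lies within the scatter) in this assay. Chloro at this position thus brings no gain in inhibition on the core of compound 3, just as bromo brought none on the core of compound 1. The true size of both steps stays unread because the read-out ends at a limit: the limit of > 100 ug/mL in this assay, at which 2 of the 4 values shown sit.

On these data alone, whether chloro on the core of compound 1 would match bromo there remains open. So does whether a methoxy or an amine at this position would retain inhibition on either core.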